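Swapping One Group on a Shared Core

The compounds below may be only part of what the source reports. "The series", "measured", "known", "first", "only" and "open" are said of these compounds alone.

In a functional assay on MCF7 cells (Homo sapiens) for antiproliferative activity, read by MTT assay, with a stated time of 48 h (on this read-out higher numbers stand for weaker inhibition and lower numbers for stronger inhibition), compound 3 `CC[Si](CC)(CC)C/C1=C/C[C@](C)(CCC=C(C)C)/C=C/[C@@H](OC(=O)C=C(C)C)[C@](C)(O)/C=C/C1=O` gives 3150 nM, the middle of three numbers. Compound 1 `CC(C)=CCC[C@]1(C)/C=C/[C@@H](OC(=O)C=C(C)C)[C@](C)(O)/C=C/C(=O)/C(C(=O)O)=C\C1` gives 16100 nM and compound 2 `CC(C)=CCC[C@]1(C)/C=C/[C@@H](OC(=O)C=C(C)C)[C@](C)(O)/C=C/C(=O)/C(CN2CCCC2)=C\C1` gives 220 nM on the same read-out. Compound 4 `CO/N=C/C1=C/C[C@](C)(CCC=C(C)C)/C=C/[C@@H](OC(=O)C=C(C)C)[C@](C)(O)/C=C/C1=O` differs from compound 3 by a group of 4 heavy atoms (2 carbon, 1 nitrogen, 1 oxygen; no ring) in place of a group of 8 heavy atoms (7 carbon, 1 silicon; no ring), on a double-bonded ring carbon on a double-bonded ring carbon. Three measured steps involve this same part of the molecule: a 73-fold lower number from compound 1 to compound 2 (1.86 log units; beyond the scatter) and a 5.1-fold lower number from compound 1 to compound 3 (0.71 log units; beyond the scatter) and also a 14-fold higher number from compound 2 to compound 3 (1.16 log units; beyond the scatter). Within the data shown here, these show that the number can move a long way here, but none of the measured compounds carries the entering group. A step within the scatter is therefore expected in this assay, if anything toward a lower number. The expected change is a 1.6-fold lower number from compound 3 to compound 4 (0.20 log units; within the scatter) overall. For compound 4 the estimated value is 2000 nM with an expected range of 500 nM to 8000 nM here.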

Compound 4, half-maximal inhibitory concentration: 2510 nM
The estimate for compound 4 lay 1.3-fold (0.10 log units) below the measured number; low and high end bracket the measured number.
By their numbers in this assay, from the lowest: compound 2; then compounds 4 and 3 (each within the scatter of the next); then compound 1.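

In this assay, a group carrying hydrogen-bond acceptors and a silicon-bearing group with none read alike at this double-bonded ring carbon: a 1.3-fold lower number from compound 3 to compound 4 (0.10 log units; within the scatter). The (pyrrolidin-1-yl)methyl group keeps a clear lead, an 11-fold higher number from compound 2 to compound 4 (1.06 log units; beyond the scatter), and the carboxy group stays well behind, a 6.4-fold lower number from compound 1 to compound 4 (0.81 log units; beyond the scatter). Nothing measured here explains these steps.

Going by these compounds, whether the low number belongs to the (pyrrolidin-1-yl)methyl group alone or to amines at this carbon more widely remains open. A morpholin-4-ylmethyl or dimethylaminomethyl group would bear on that question.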